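The source may hold more compounds than are shown below. What is called first, only, known or untested is meant among the compounds shown, and "the series" means these compounds.

Measured compounds:
Compound 1 `O=C1Oc2ccccc2N/C1=C\C(=O)c1cccs1`: > 1840000 nM in an ADME assay on Vero cells (Chlorocebus sabaeus) for cytotoxicity, read by MTT assay, with a stated time of 72 h; on this read-out lower numbers stand for higher toxicity in this test and higher numbers for lower toxicity in this test
Compound 2 `O=C1/C(=C/c2ccccc2Cl)Oc2ccccc2N1Cc1ccccc1`: "not determined" (no result reported) in this assay

Compound 1 stands only at the edge of the numbers shown: its value in this assay is a limit of the assay and not a number, as the limit of > 1840000 nM in this assay, at which 1 of the 2 values shown sits, records. For compound 2 no result was reported. Compound 3 `Cc1ccccc1C(=O)/C=C1\Nc2ccccc2OC1=O` differs from compound 1 by 2-methylphenyl in place of thiophen-2-yl on a carbonyl carbon. For the measured compounds named here, no measured step frames this change, so the account expects at most a shift within the scatter in this assay, with no direction beyond it. Compound 3 is therefore estimated at 1500000 nM (range 300000 nM to 3000000 nM), a step of an at least 1.2-fold lower number from compound 1 to compound 3 (0.08 log units; that floor lies within the scatter) that is expected to be small.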

Compound 3, half-maximal cytotoxic concentration: > 1790000 nM
Compound 3 was reported as a limit (the forecaster's own chance of this, stated with the estimate: 70%); middle value at least 1.1-fold (0.07 log units) from the limit.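

For the compounds shown here, compound 1 and compound 3 are both reported only as limits in this assay, and no step between them can be read. On these data alone, whether 2-methylphenyl in place of thiophen-2-yl on a carbonyl carbon shifts the half-maximal cytotoxic concentration at all remains open.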